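Sulfonamide nitrogen substituents on the chlorocoumarin imine series

The compounds below may be only part of what the source reports. "The series", "measured", "known", "first", "only" and "open" are said of these compounds alone.

The shared core carries an aryl sulfonamide whose nitrogen is varied. Compound 1 `NS(=O)(=O)c1ccc(/N=C/c2c(Cl)c3ccccc3oc2=O)cc1` has hydrogen on that nitrogen and in a functional assay on MCF7 cells (Homo sapiens) for cytotoxicity, read by CCK-8 assay, with a stated time of 48 h (on this read-out lower numbers stand for stronger inhibition and higher numbers for weaker inhibition), compound 1 gives 120 nM. Compound 2 `O=c1oc2ccccc2c(Cl)c1/C=N/c1ccc(S(=O)(=O)Nc2nccs2)cc1` carries 1,3-thiazol-2-yl there; in this assay compound 2 gives 160 nM. Compound 3 `N=C(N)NS(=O)(=O)c1ccc(/N=C/c2c(Cl)c3ccccc3oc2=O)cc1` carries the three-atom group; in this assay compound 3 gives 58 nM.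

For the measured compounds named here, compound 2 has the highest of the three numbers, but the step of a 1.3-fold higher number from compound 1 to compound 2 (0.12 log units; within the scatter) is within the scatter, so compound 1 and compound 2 cannot be told apart; only the step of a 2.8-fold lower number from compound 2 to compound 3 (0.44 log units; beyond the scatter) lies beyond it, as does a 2.1-fold lower number from compound 1 to compound 3 (0.32 log units; beyond the scatter).

Compound 4 `Cc1cc(C)nc(NS(=O)(=O)c2ccc(/N=C/c3c(Cl)c4ccccc4oc3=O)cc2)n1` is not yet measured. Its change from compound 2 is 4,6-dimethylpyrimidin-2-yl in place of 1,3-thiazol-2-yl on a sulfonamide nitrogen. Going by the values given here, no measured step exchanges one ring for another on this nitrogen. The nearest guides are the within-scatter step from compound 1 to compound 2 and the modest step from compound 2 to compound 3, which together show that this position tolerates change with little movement in this assay. An expected step of a 1.1-fold higher number from compound 2 to compound 4 (0.03 log units; within the scatter) is therefore estimated, none beyond the scatter. In this assay compound 4 is expected to give 170 nM, within a range of 80 nM to 360 nM.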

Compound 4, half-maximal inhibitory concentration: 20 nM
Compound 4: the middle estimate sits 8.5-fold (0.93 log units) above what was measured, outside the stated range (below it).
By their numbers in this assay, from the lowest: compound 4; then compound 3; then compounds 1 and 2 (each within the scatter of the next).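

For the compounds shown here, on the sulfonamide nitrogen, exchanging one ring for another is not neutral: in this assay the change from 1,3-thiazol-2-yl to 4,6-dimethylpyrimidin-2-yl gives an 8.0-fold lower number from compound 2 to compound 4 (0.90 log units; beyond the scatter), although the earlier compounds had suggested little movement at this position. The new group also separates from the other two substituents, with a 2.9-fold lower number from compound 3 to compound 4 (0.46 log units; beyond the scatter) and a 6.0-fold lower number from compound 1 to compound 4 (0.78 log units; beyond the scatter), so a ring on this nitrogen can give the lowest number of the four, while the 1,3-thiazol-2-yl ring of compound 2 stays within the scatter of the hydrogen of compound 1. No measurement is available that would explain this gain.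

Still open, from the compounds shown here alone, is whether the step follows from the six-membered ring itself or from its methyl groups, a question that an unsubstituted pyrimidin-2-yl or a 4-methylpyrimidin-2-yl on the same nitrogen would address. Also open is how a plain phenyl on this nitrogen would compare with the rings shown, and whether the low number of compound 4 carries over to other cell lines.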